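The source may hold more compounds than are shown below. What is called first, only, known or untested is meant among the compounds shown, and "the series" means these compounds.

Of the compounds shown here, two have been tested so far, and neither gives an exact number. In a functional assay on HCT-116 cells (Homo sapiens), read by MTT assay, with a stated time of 72 h (on this read-out lower numbers stand for stronger inhibition and higher numbers for weaker inhibition), compound 1 (`CSc1ncnc2c1c(-c1cccs1)cn2[C@@H]1O[C@H](CO)[C@@H](O)[C@H]1O`) gives > 20000 nM as its result, which is a limit and not a measured value. In this assay compound 2 (`CNc1ncnc2c1c(-c1ccoc1)cn2[C@@H]1O[C@H](CO)[C@@H](O)[C@H]1O`) gives > 20000 nM as its result, again a limit and not a measured value. Compound 2 therefore has no exact place on the scale, and the whole picture so far is the limit of > 20000 nM in this assay, at which 2 of the 2 values shown sit, and nothing more.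

Compound 3 (`CNc1ncnc2c1c(-c1cccs1)cn2[C@@H]1O[C@H](CO)[C@@H](O)[C@H]1O`) changes compound 2 in one place: thiophen-2-yl in place of furan-3-yl on an aromatic carbon. Within the data shown here, no pair of measured compounds shows what such a swap does, so any forecast is uncertain. In this assay a modest shift toward stronger inhibition is expected because compound 2 sits at > 20000 nM and a weaker result could not be told apart from that limit. The expected move an at least 2.0-fold lower number from compound 2 to compound 3 (0.30 log units; that floor lies within the scatter) is only an estimate. For compound 3 the estimate is 10000 nM with an expected range from 1500 nM to 20000 nM and a good chance that the outcome will be only a limit.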

Compound 3, half-maximal inhibitory concentration: > 20000 nM
Compound 3 gave a limit, no number; the forecaster's own chance of this, stated with the estimate: 55%; at least 2.0-fold (0.30 log units) between middle value and limit.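

In this assay compound 3 also gives only a limit, so neither its step from compound 2 nor its step from compound 1 can be read; all three compounds share one result: the limit of > 20000 nM in this assay, at which 3 of the 3 values shown sit.

The compounds shown leave open whether thiophen-2-yl in place of furan-3-yl, or methylamino in place of methylsulfanyl, changes inhibition at all.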